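Secondary versus tertiary amine on the shared core

The source may hold more compounds than are shown below. What is called first, only, known or untested is meant among the compounds shown, and "the series" means these compounds.

Compound 1 (`CCCNc1nc(C)nc2c1cnn2-c1ccccc1`) gives 36000 nM in a functional assay on G-361 cells (Homo sapiens) for cytotoxicity, read by sulforhodamine B assay; on this read-out lower numbers stand for stronger inhibition of growth and higher numbers for weaker inhibition of growth.
Compound 2 (`CCN(CC)c1nc(C)nc2c1cnn2-c1ccccc1`) gives > 100000 nM in this assay, which is a limit of the assay and not a number.
Compound 3 (`CCNc1nc(C)nc2c1cnn2-c1ccccc1`) is not yet measured in this assay.

Compound 2 thus stands at the weak end of the two values shown, at the limit (the limit of > 100000 nM in this assay, at which 1 of the 2 values shown sits). For the measured compounds named here, the one measured step, an at least 2.7-fold higher number from compound 1 to compound 2 (0.44 log units; beyond the scatter), moves in the weakening direction and lies beyond the scatter. The step to compound 3 is hydrogen in place of ethyl on a nitrogen on an aromatic ring, which returns the tertiary amine to a secondary one, so it runs against the direction of that measured step. A lowering of the number beyond the scatter is therefore expected, though only the limit on compound 2 bounds it. Compound 3 is expected near 40000 nM, in the range 15000 nM to 100000 nM. The expected step is an at least 2.5-fold lower number from compound 2 to compound 3 (0.39 log units; beyond the scatter).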

Compound 3, concentration for 50% growth inhibition: 38700 nM
Compound 3: middle estimate off by 1.0-fold (0.01 log units), on the high side; low and high end bracket the measured number.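

Among the three compounds, the secondary amines separate from the tertiary one at this position: removing one ethyl from diethylamino gives an at least 2.5-fold lower number from compound 2 to compound 3 (0.41 log units; beyond the scatter). Chain length on the secondary amine does not separate ethylamino from propylamino in this assay, where the comparison reads a 1.1-fold higher number from compound 1 to compound 3 (0.03 log units; within the scatter). The reading for compound 2 is a limit and not a number, so the step to compound 3 has no defined upper size: the limit of > 100000 nM in this assay, at which 1 of the 3 values shown sits.

As far as these compounds go, whether the same flat reading holds for a plain amino group, methylamino or a longer chain such as butylamino remains open. Also open, from the compounds shown here alone, is whether a cyclic tertiary amine such as morpholine or piperidine would read like diethylamino, or whether a secondary amine bearing a benzyl group would read like ethylamino and propylamino.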